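Swapping a piperazine substituent: imidazolylmethyl to phenyl

The source may hold more compounds than are shown below. What is called first, only, known or untested is meant among the compounds shown, and "the series" means these compounds.

Measured compounds:
- compound 1, `c1c[nH]c(CN2CCN(CCCc3c[nH]c4ccc(-n5cnnc5)cc34)CC2)n1`: 1.6 nM
- compound 2, `CN(C)C(=O)C(c1ccccc1)N1CCN(CCCc2c[nH]c3ccc(-n4cnnc4)cc23)CC1`: 1 nM

Both compounds were tested in an assay on CHO cells for displacement of a labelled ligand from 5-hydroxytryptamine receptor 1D (Homo sapiens); a higher number here means a weaker inhibitor, a lower number a stronger inhibitor. Compound 1 gives 1.6 nM, the higher of the two numbers, while compound 2 gives 1 nM; the gap between them falls within the usual scatter, so the two cannot be told apart.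

Compound 3, `c1ccc(N2CCN(CCCc3c[nH]c4ccc(-n5cnnc5)cc34)CC2)cc1`, has not yet been measured. It differs from compound 1 in one place: phenyl in place of (1H-imidazol-2-yl)methyl on an amine nitrogen in a ring. For the measured compounds named here, no comparable change between two measured compounds is available, so the only guide is that both measured compounds, which carry different groups on this ring nitrogen, sit close together. Compound 3 is therefore expected to show a small step from compound 1, a 1.3-fold higher number from compound 1 to compound 3 (0.10 log units; within the scatter), in no particular direction beyond the scatter. Compound 3 is estimated at 2 nM, with a range from 0.5 nM to 8 nM.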

Compound 3, half-maximal inhibitory concentration: 1.4 nM
For compound 3 the middle estimate is 1.4-fold (0.15 log units) above the measured one; the range from low to high includes it.
By their numbers in this assay, from the lowest: compounds 2, 3 and 1 (each within the scatter of the next).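

In this assay, putting phenyl in place of (1H-imidazol-2-yl)methyl on the ring nitrogen gives a 1.1-fold lower number from compound 1 to compound 3 (0.06 log units; within the scatter), so compound 1 and compound 3 cannot be told apart. For the compounds shown here, this is the first one-place comparison at this position, and it shows that the hydrogen-bond donor and acceptor counted on the (1H-imidazol-2-yl)methyl group can be absent from the incoming phenyl with no step beyond the scatter in this assay. Nothing measured here explains this result.

Every group shown on this ring nitrogen contains an aromatic ring, so it remains open whether a plain methyl would give a similar number. From the compounds shown here alone, it is equally open whether a carboxylic acid or a primary amine at the end of a short chain in that place would do so.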